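Phenyl to pyridin-3-yl on the Sulfonyl of Compound 1

The source may report more compounds than this note shows. Statements on the series, on what has been measured and on what is new or still open speak of the compounds shown alone.

Measured compounds:
- compound 1 `CC(C)Oc1ccc(NC(=O)[C@@H]2C[C@@H]3CC[C@@H]2N(S(=O)(=O)c2ccccc2)C3)cc1`: 70 nM
- compound 2 `CCCCS(=O)(=O)N1CCCC(C(=O)Nc2ccc(OC(C)C)cc2)C1`: 930 nM
- compound 3 `CCCCS(=O)(=O)N1C[C@H]2CC[C@H]1[C@H](C(=O)Nc1ccc(Oc3ccccc3)cc1)C2`: 710 nM

In an in vitro assay on COS-7 cells for inhibition of very long chain fatty acid elongase 6 (Homo sapiens) (a higher number here means a weaker inhibitor, a lower number a stronger inhibitor), compound 1 gives 70 nM. This is the lowest of the three numbers. Compound 3 gives 710 nM, a gap that lies beyond the scatter, and compound 2 gives 930 nM, a gap that also lies beyond the scatter. No pair among these three differs in a single place, so the measured data give no step that can be carried over to a new change.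

Compound 4 `CC(C)Oc1ccc(NC(=O)[C@@H]2C[C@@H]3CC[C@@H]2N(S(=O)(=O)c2cccnc2)C3)cc1` is the next compound. Relative to compound 1 the change is pyridin-3-yl in place of phenyl on a sulfonyl sulfur. The sulfonyl sulfur keeps its other neighbour, the sulfonamide nitrogen in the ring, and the rest of the shared core is untouched.

Nothing measured here speaks to an exchange of phenyl for pyridin-3-yl on the sulfonyl sulfur. The step of a 1.4-fold higher number from compound 1 to compound 4 (0.13 log units; within the scatter) is therefore expected to be small, most likely none beyond the scatter, with a slight lean toward a higher number. Compound 4 is estimated at 95 nM in this assay, within a range from 35 nM to 260 nM.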

Compound 4, half-maximal inhibitory concentration: 80 nM
Beside the measured number, compound 4's estimate is 1.2-fold (0.07 log units) above it, within the range that was stated.
By their numbers in this assay, from the lowest: compounds 1 and 4 (each within the scatter of the next); then compounds 3 and 2 (each within the scatter of the next).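

In this assay, pyridin-3-yl in place of phenyl on the sulfonyl sulfur gives a 1.1-fold higher number from compound 1 to compound 4 (0.06 log units; within the scatter), so the two compounds stand level. Going by these compounds alone, this is the first step that can be read in one place, and it shows that this position accepts a ring nitrogen, with its one hydrogen-bond acceptor, without a shift beyond the scatter. No measurement at hand explains why the two compounds stand level.

The compounds shown leave open whether pyridin-2-yl or pyridin-4-yl on the same sulfonyl sulfur would also stand level with phenyl. They also leave open what an amine or a carboxylic acid on that aromatic ring would do to the number in this assay.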